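Swapping a Sulfonamide for a Cyclohexyl Amide

The compounds below may be only part of what the source reports. "The series", "measured", "known", "first", "only" and "open" are said of these compounds alone.

Of the compounds shown here, three sharing one core have been measured in an assay on blood for inhibition of Indoleamine 2,3-dioxygenase 1 (Homo sapiens), read by mass spectrometry, with stated times of 4 h and 18 h; a higher number here means a weaker inhibitor, a lower number a stronger inhibitor. Compound 2 `C[C@@H](NS(=O)(=O)c1ccc(Cl)cc1)[C@H]1CC[C@@H](c2ccnc3ccc(F)cc32)CC1` gives 484 nM in this assay. Compound 3 `C[C@@H](CNC(=O)c1ccc(Cl)cc1)[C@H]1CC[C@@H](c2ccnc3ccc(F)cc32)CC1` gives 158 nM in this assay, a lower number than compound 2, and the gap between them is beyond the usual scatter. Compound 1 `C[C@H](NC(=O)[C@H](C)[C@H]1CC[C@@H](c2ccnc3ccc(F)cc32)CC1)c1ccc(Cl)cc1` reaches only a limit of the assay, > 1000 nM, so no number is known for it (the limit of > 1000 nM in this assay, at which 1 of the 3 values shown sits). Among the two compounds with numbers, compound 2 therefore has the higher one.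

Compound 4 `C[C@@H](NC(=O)C1CCCCC1)[C@H]1CC[C@@H](c2ccnc3ccc(F)cc32)CC1` has not yet been measured. It differs from compound 2 in one place: cyclohexylcarbonyl in place of (4-chlorophenyl)sulfonyl on an amine nitrogen. Within the data shown here, no measured pair shows exactly this kind of exchange, so the size and direction of the step cannot be read from the data. The expectation is a step of a 1.1-fold lower number from compound 2 to compound 4 (0.03 log units; within the scatter) in this assay, that is, no clear change beyond the scatter. Compound 4 is therefore estimated at 450 nM, with a range from 120 nM to 1800 nM.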

Compound 4, half-maximal inhibitory concentration: 294 nM
Beside the measured number, compound 4's estimate is 1.5-fold (0.18 log units) above it; the range from low to high includes it.
By their numbers in this assay, from the lowest: compounds 3, 4 and 2 (each within the scatter of the next, the first and the last beyond it). At a limit, above all of these: compound 1.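

In this assay, cyclohexylcarbonyl in place of (4-chlorophenyl)sulfonyl on this amine nitrogen gives a 1.6-fold lower number from compound 2 to compound 4 (0.22 log units; within the scatter), so the two compounds cannot be told apart. Among these compounds, this is the first view of a non-aromatic carbon ring at this position, and it shows that a number in the same range does not depend on the aromatic ring, the chlorine or the sulfur. Nothing given here explains why the two values are so close.

The exchange alters the ring and the link to the nitrogen together, so the compounds shown do not separate the two; a 4-chlorobenzoyl group on the same nitrogen would do so. On these data alone, whether any ring is needed at all also remains open, and a plain acetyl group there would address it.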